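The compounds below may be only part of what the source reports. "The series", "measured", "known", "first", "only" and "open" are said of these compounds alone.

Measured in a functional assay on HCT-116 cells (Homo sapiens), read by MTT assay, with a stated time of 72 h (a higher number here means a weaker inhibitor, a lower number a stronger inhibitor), each value a limit of the assay and not a number:

compound 1 `CNc1ncnc2c1c(-c1ccoc1)cn2[C@@H]1O[C@H](CO)[C@@H](O)[C@H]1O`: > 20000 nM
compound 2 `CN(C)c1ncnc2c1c(-c1cc3ccccc3o1)cn2[C@@H]1O[C@H](CO)[C@@H](O)[C@H]1O`: > 20000 nM
compound 3 `Nc1nc2c(c(-c3ccco3)cn2[C@@H]2O[C@H](CO)[C@@H](O)[C@H]2O)c(=O)[nH]1`: > 20000 nM

Compound 3 gives no number in this assay, only the limit > 20000 nM. It stands level with the other two compounds, and the whole record reads (the limit of > 20000 nM in this assay, at which 3 of the 3 values shown sit).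

Next to be read is compound 4 `Nc1nc2c(c(-c3cccs3)cn2[C@@H]2O[C@H](CO)[C@@H](O)[C@H]2O)c(=O)[nH]1`, which has thiophen-2-yl in place of furan-2-yl on an aromatic carbon. The rest of the structure of compound 3 is kept.

Going by the values given here, no measured pair gives the size of any single change, so nothing here scales this swap directly. Both groups are five-membered aromatic rings with 1 hetero atom and the same heavy-atom count. The working expectation for compound 4 is therefore no step beyond the usual scatter in this assay, and most likely another limit, since compound 3 reads > 20000 nM. If a number does appear, it can only lie on the stronger side of that limit. The estimated change is an at least 1.3-fold lower number from compound 3 to compound 4 (0.12 log units; that floor lies within the scatter). For compound 4 the estimated value is 15000 nM, with an expected range of 4000 nM to 20000 nM.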

Compound 4, half-maximal inhibitory concentration: > 20000 nM
Compound 4: no number, only a limit; the forecaster's own chance of this, stated with the estimate: 70%; middle value at least 1.3-fold (0.12 log units) from the limit.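

In this assay compound 4 gives > 20000 nM, a limit of the assay and not a number. With compound 3 also reading only as a limit, no step can be read between compound 3 and compound 4: the limit of > 20000 nM in this assay, at which 4 of the 4 values shown sit.

The compounds shown leave open what size the swap of furan-2-yl for thiophen-2-yl has, and which structural change, if any, would give a number in this assay.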